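A few compounds are considered here, and "the series" means these few. Any claim that something is new, unique, unknown or untested is made for them only; others in the source may bear on it.

In a functional assay on HepG2 cells (Homo sapiens) for antiproliferative activity, read by MTT assay, with a stated time of 48 h (on this read-out lower numbers stand for stronger inhibition and higher numbers for weaker inhibition), compound 1 `CCn1c(C(=O)NCCN(C)C)ccc1C(CC)(CC)c1ccc(OCCC(O)(CC)CC)c(C)c1` gives 240 nM and compound 2 `CCN(CC)CCNC(=O)c1ccc(C(CC)(CC)c2ccc(OCCC(O)(CC)CC)c(C)c2)n1CC` gives 230 nM, with a 1.0-fold lower number from compound 1 to compound 2 (0.02 log units; within the scatter). Compound 3 `CCn1c(C(=O)N(CCC#N)CCC#N)ccc1C(CC)(CC)c1ccc(OCCC(O)(CC)CC)c(C)c1` stands highest of the three at 46300 nM. Compound 4 `C=CCN(C)C(=O)c1ccc(C(CC)(CC)c2ccc(OCCC(O)(CC)CC)c(C)c2)n1CC` differs from it on the carbonyl carbon: a group of 5 heavy atoms (4 carbon, 1 nitrogen; no ring) in place of a group of 9 heavy atoms (6 carbon, 3 nitrogen; no ring), on a carbonyl carbon. Going by the values given here, no measured step covers this exchange directly. The nearest evidence is a 190-fold higher number from compound 1 to compound 3 (2.29 log units; beyond the scatter) and a 200-fold higher number from compound 2 to compound 3 (2.30 log units; beyond the scatter), both changes on the same carbonyl carbon. Compound 4 carries neither the dimethylamino nor the diethylamino group, so only a partial return towards those values is expected. In this assay the expected change is a lower number, estimated as a 7.7-fold lower number from compound 3 to compound 4 (0.89 log units; beyond the scatter). The estimate for compound 4 is 6000 nM, with an expected range of 800 nM to 40000 nM.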

Compound 4, half-maximal inhibitory concentration: > 50000 nM
Compound 4 ended at the assay's limit; the forecaster's own chance of this, stated with the estimate: 10%; middle value at least 8.3-fold (0.92 log units) from the limit.
By their numbers in this assay, from the lowest: compounds 2 and 1 (each within the scatter of the next); then compound 3. At a limit, above all of these: compound 4.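

Allyl(methyl)amino on the carbonyl carbon, a smaller group than in compound 3 and one without nitrile, does not restore the low numbers of the amine-bearing amides: the readings are an at least 200-fold higher number from compound 1 to compound 4 (2.31 log units; beyond the scatter) and an at least 210-fold higher number from compound 2 to compound 4 (2.33 log units; beyond the scatter). Against the nitrile-bearing amide, the reading is only an at least 1.0-fold higher number from compound 3 to compound 4 (0.03 log units; that floor lies within the scatter), so the order of those two stays open. Compound 4 stands at a limit: the limit of > 50000 nM in this assay, at which 1 of the 4 values shown sits.

Compounds 1 and 2 carry both the amide hydrogen and a terminal amine, while compounds 3 and 4 carry neither, so the two features remain unseparated. A (2-(dimethylamino)ethyl)(methyl)amino group or a plain propylamino group on the carbonyl carbon would separate them.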